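Methyl in place of hydrogen at two different places

The source may report more compounds than this note shows. Statements on the series, on what has been measured and on what is new or still open speak of the compounds shown alone.

Compound 1 `CS(=O)(=O)c1ccc(Nc2ncc(F)c(Nc3nc4ccccc4s3)n2)cc1` is the reference point of this small set. In a functional assay on MCF7 cells (Homo sapiens) for antiproliferative activity, read by MTT assay, with a stated time of 48 h (a lower number here means a stronger inhibitor, a higher number a weaker inhibitor), compound 1 gives 6880 nM. Compound 2 `Cc1ccc2nc(Nc3nc(Nc4ccc(S(C)(=O)=O)cc4)ncc3F)sc2c1` carries the change (methyl in place of hydrogen on an aromatic carbon). For compound 2 the read-out is a limit of the assay, > 50000 nM. The resulting step is an at least 7.2-fold higher number from compound 1 to compound 2 (0.86 log units; beyond the scatter), and its true size is known only up to the limit of > 50000 nM in this assay, at which 1 of the 3 values shown sits.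

Compound 3 `NS(=O)(=O)c1ccc(Nc2nccc(Nc3nc4ccc(F)cc4s3)n2)cc1` belongs to the same series, but the difference between its core and the core of compound 1 is not broken down here. In this assay compound 3 gives 10900 nM; set against compound 1 this lies within the usual scatter, so no order is drawn between the two.

Compound 4 `Cc1cnc(Nc2ccc(S(N)(=O)=O)cc2)nc1Nc1nc2ccc(F)cc2s1` has not yet been measured. It differs from compound 3 by methyl in place of hydrogen on an aromatic carbon. This is the same kind of change as that from compound 1 to compound 2, but not the same: there the methyl entered on an aromatic carbon of a six-membered aromatic ring of carbon only, part of a fused or bridged system of two rings, meta to a fused ring and para to a fused ring; here it enters on a six-membered aromatic ring with 2 nitrogen, ortho to a large group, two atoms from the ring nitrogen, para to a large group. Going by the values given here, the one measured precedent therefore transfers only loosely. For compound 4 the expected step is a 1.8-fold higher number from compound 3 to compound 4 (0.26 log units; within the scatter), a guarded reading of the step of an at least 7.2-fold higher number from compound 1 to compound 2 (0.86 log units; beyond the scatter) carried to a different place. Compound 4 is accordingly estimated at 20000 nM, with 6000 nM to 60000 nM as the expected range.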

Compound 4, half-maximal inhibitory concentration: > 50000 nM
Compound 4: only a limit was reported; the forecaster's own chance of this, stated with the estimate: 25%; at least 2.5-fold (0.39 log units) between middle value and limit.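

In this assay compound 4 gives > 50000 nM, which is a limit of the assay and not a number: the limit of > 50000 nM in this assay, at which 2 of the 4 values shown sit. Methyl in place of hydrogen on the six-membered aromatic ring with 2 nitrogen gives an at least 4.5-fold higher number from compound 3 to compound 4 (0.66 log units; beyond the scatter), the same direction as an at least 7.2-fold higher number from compound 1 to compound 2 (0.86 log units; beyond the scatter), where the methyl sits on a six-membered aromatic ring of carbon only, so on these two cores the change goes with a higher number at both places. This shows that the direction carries from one core to the other in these two pairs, but it gives no true size for either step and no ranking of the two places: the same change on two cores in this assay, an at least 7.2-fold higher number (0.86 log units; beyond the scatter) from compound 1 to compound 2 and an at least 4.5-fold higher number (0.66 log units; beyond the scatter) from compound 3 to compound 4; the limit leaves it open whether they differ.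

The compounds shown leave open whether the higher number is tied to methyl itself or would also follow from another group at either place, such as an ethyl chain, a methoxy group or an amine. They also leave open how large either step really is, and a change that keeps the read-out inside the measurable range of the assay would be needed to settle that.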